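The compounds below may be only part of what the source reports. "The series", "measured", "known", "first", "only" and "open" are said of these compounds alone.

Measured so far in a functional assay on HepG2 cells (Homo sapiens) for inhibition, read by MTT assay, with a stated time of 24 h; on this read-out lower numbers stand for stronger inhibition and higher numbers for weaker inhibition:
compound 1 `CC1(C)[C@H]2CC[C@]1(C)N(Cc1cn(-c3cccc(F)c3)nn1)C(=O)C2`: 80 nM
compound 2 `CC1(C)[C@H]2CC[C@]1(C)N(Cc1cn(-c3ccc(C#N)cc3)nn1)C(=O)C2`: 50 nM
compound 3 `CC1(C)[C@H]2CC[C@]1(C)N(Cc1cn(-c3cccc(Br)c3)nn1)C(=O)C2`: 20 nM

Compound 3 gives the lowest number of the three. Next is compound 4 `COc1ccc(-n2cc(CN3C(=O)C[C@@H]4CC[C@@]3(C)C4(C)C)nn2)cc1`, not yet measured. The change is 4-methoxyphenyl in place of 3-bromophenyl on an aromatic nitrogen. Two measured steps end at the same position in compound 3: a 4.0-fold lower number from compound 1 to compound 3 (0.60 log units; beyond the scatter) and a 2.5-fold lower number from compound 2 to compound 3 (0.40 log units; beyond the scatter). Both are modest and beyond the scatter, and each shows a number lower than that of the compound it starts from. The step of a 1.6-fold lower number from compound 1 to compound 2 (0.20 log units; within the scatter) lies within the scatter. Among the compounds with values here, no measured compound carries a methoxy group, so the direction rests only on the two compounds that lack the 3-bromophenyl group. A modest step to a higher number is therefore expected in this assay, though none beyond the scatter remains possible. The expected step is a 3.0-fold higher number from compound 3 to compound 4 (0.48 log units; beyond the scatter). The estimated value for compound 4 is 60 nM. The expected range for compound 4 runs from 20 nM to 200 nM.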

Compound 4, half-maximal inhibitory concentration: 100 nM
Compound 4: middle estimate off by 1.7-fold (0.22 log units), on the low side; the range from low to high includes it.
By their numbers in this assay, from the lowest: compound 3; then compounds 2, 1 and 4 (each within the scatter of the next).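

In this assay the first methoxy compound gives a 5.0-fold higher number from compound 3 to compound 4 (0.70 log units; beyond the scatter) and this step lies beyond the scatter, so compound 3 now stands apart from all three other compounds. The steps of a 2.0-fold higher number from compound 2 to compound 4 (0.30 log units; within the scatter) and a 1.3-fold higher number from compound 1 to compound 4 (0.10 log units; within the scatter) both lie within the scatter, so 4-methoxyphenyl cannot be told apart from 4-cyanophenyl or 3-fluorophenyl at this position on the aromatic nitrogen, and only the 3-bromophenyl group separates from the rest. No measured evidence on hand accounts for the separation of compound 3.

Going by these compounds, it remains open whether the low number of compound 3 goes with the bromo group itself or with its place on the phenyl ring. Also open, on these data alone, is how a 4-bromophenyl or 3-methoxyphenyl group, or a phenyl ring carrying an amine or a carboxylic acid, would stand against compound 3.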